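The source may hold more compounds than are shown below. What is called first, only, known or untested is meant among the compounds shown, and "the series" means these compounds.

Measured so far in an ADME assay on Huh-7 cells (Homo sapiens) for cytotoxicity, read by XTT assay, with a stated time of 3 days, tested at 200 uM; a lower number here means a stronger effect, a higher number a weaker effect of the compound at the concentration tested: compound 1 `Fc1ccc(-n2nc(-c3ccccc3)cc2-c2ccc3cc(F)ccc3n2)cc1` gives 91.6%; compound 2 `COc1ccc(-n2nc(-c3ccccc3)cc2-c2ccc3cc(F)ccc3n2)cc1` gives 97.4%; compound 3 `NS(=O)(=O)c1ccc(-n2nc(-c3ccc(F)cc3)cc2-c2ccc3cc(F)ccc3n2)cc1` gives 43%.

Compound 1 and compound 2 share one core and differ in a single place, namely (methoxy in place of fluoro on an aromatic carbon). In this assay this change produced a number 5.8 percentage points higher from compound 1 to compound 2 (within the scatter), so the two values cannot be told apart. Compound 3 rests on a different core, and the difference between the two cores is not broken down here. What the numbers do show is that compound 3 sits well apart from both compound 1 and compound 2, beyond the scatter in each case.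

Compound 4 `COc1ccc(-c2cc(-c3ccc4cc(F)ccc4n3)n(-c3ccc(S(N)(=O)=O)cc3)n2)cc1` is the still unmeasured partner of compound 3. It differs from compound 3 by methoxy in place of fluoro on an aromatic carbon, the same change, at the same place, as that from compound 1 to compound 2. Because the earlier step of a number 5.8 percentage points higher from compound 1 to compound 2 (within the scatter) stayed within the scatter, a similarly small step a number 5 percentage points higher from compound 3 to compound 4 (within the scatter) is expected here. Compound 4 is therefore estimated at 48% in this assay, most likely between 32% and 68%.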

Compound 4, a percentage reported as activity, at one concentration (the size of the read-out at that concentration, not a potency): 89.5%
The estimate for compound 4 lay 41.5 percentage points below the measured number; the measured number lies above the stated range.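

Putting methoxy in place of fluoro, the change from 4-fluorophenyl to 4-methoxyphenyl, on the core of compound 3 gave a number 46.5 percentage points higher from compound 3 to compound 4 (beyond the scatter) in this assay. Among the compounds shown here, the size of this change therefore did not carry over between the two cores, and a small step on one core was no guide to the step on the other: the same change on two cores in this assay, a number 5.8 percentage points higher (within the scatter) from compound 1 to compound 2 and a number 46.5 percentage points higher (beyond the scatter) from compound 3 to compound 4, 40.7 percentage points apart, beyond the scatter of two such steps. For the compounds shown here, this rests on only two pairs of compounds, so it does not show which difference between the cores matters, nor does it give a rule for other cores.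

The compounds shown leave open whether the large step belongs to methoxy itself or would also appear with another group, such as an amine, a hydroxyl or a longer ethoxy chain, in place of the methoxy of compound 4. They also leave open how a carboxylic acid in place of the sulfonamide of compound 4 would read in this assay.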